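The source may hold more compounds than are shown below. What is called first, only, known or untested is meant among the compounds shown, and "the series" means these compounds.

Compound 1 `COc1cc(-c2cc(/C=C/C(=O)c3ccc(Cl)c(Cl)c3)[nH]n2)cc(OC)c1OC` is the anchor of this account. In a functional assay on OVCAR-8 cells (Homo sapiens) for cytotoxicity, read by sulforhodamine B assay, with a stated time of 48 h, tested at 1 uM (a higher number here means a weaker effect of the compound at the concentration tested, a lower number a stronger effect), compound 1 gives 88%, the top number among the three measured. Compound 2 `COc1ccc(-c2cc(/C=C/C(=O)c3cc(OC)c(OC)c(OC)c3)[nH]n2)cc1OC` gives 80%, a number that sits within the usual scatter of compound 1, whereas compound 3 `COc1ccc(-c2cc(/C=C/C(=O)c3ccc(N)cc3)[nH]n2)cc1` gives 76%, which lies beyond that scatter. The move to compound 4 `COc1cc(-c2cc(/C=C/C(=O)c3ccc(F)c(F)c3)[nH]n2)cc(OC)c1OC` changes a single place: 3,4-difluorophenyl in place of 3,4-dichlorophenyl on a carbonyl carbon. The 3,4-dichlorophenyl leaves and a 3,4-difluorophenyl enters on the carbonyl carbon. Within the data shown here, no measured pair shows this change, so its step in this assay can only be expected, and the expectation is for no step beyond the scatter in either direction. Compound 4 is therefore estimated to give 89%, with a range from 76% to 100%. That estimate means an expected step of a number 1 percentage points higher from compound 1 to compound 4 (within the scatter).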

Compound 4, a percentage reported as activity, at one concentration (the size of the read-out at that concentration, not a potency): 89%
Estimate against measurement, compound 4: no gap at the digits printed; measured number inside the range.
By their numbers in this assay, from the lowest: compounds 3, 2, 1 and 4 (each within the scatter of the next, the first and the last beyond it).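

With 3,4-difluorophenyl in place of 3,4-dichlorophenyl on the carbonyl carbon, this assay shows a number 1 percentage points higher from compound 1 to compound 4 (within the scatter). Among these compounds, this single pair gives the first measured reading at this place: the exchange of one halogen pair for the other, on an otherwise unchanged compound, leaves the read-out within the scatter. No evidence is available on why the two groups read alike. The compounds shown leave open whether a carboxylic acid or a dimethylamino group on this phenyl ring would move the number beyond the scatter. From the compounds shown here alone, a single chlorine in place of the pair remains equally open.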